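The source may hold more compounds than are shown below. What is called first, only, known or untested is meant among the compounds shown, and "the series" means these compounds.

Within the data shown here, in a functional assay on HCT-116 cells (Homo sapiens) for cytotoxicity, read by MTT assay, with a stated time of 72 h (on this read-out lower numbers stand for stronger inhibition and higher numbers for weaker inhibition), compound 1 `CN1C/C(=C\c2cc(F)c(F)cc2F)C(=O)/C(=C/c2cc(F)c(F)cc2F)C1` gives 1500 nM, and this is the only exact number available so far. Compound 2 `CN1C/C(=C\c2c(F)cc(F)cc2F)C(=O)/C(=C/c2c(F)cc(F)cc2F)C1` is reported only as a limit of the assay, > 10000 nM. Compound 1 is therefore the one firm reference point for what follows.

Compound 3 `CCN1C/C(=C\c2cc(F)c(F)cc2F)C(=O)/C(=C/c2cc(F)c(F)cc2F)C1` keeps the core of compound 1 and changes it in one place: methyl in place of hydrogen on a saturated chain carbon bound to an amine nitrogen in a ring. Put another way, the same difference reads as methyl to ethyl.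

Among the measured compounds shown here, no measured pair of compounds here shows what this change does. The expectation therefore rests on the small size of the change and on compound 1 at 1500 nM. In this assay, no shift beyond the usual scatter is expected, and neither direction is favoured. The expected 1.1-fold lower number from compound 1 to compound 3 (0.03 log units; within the scatter) is accordingly small. Compound 3 is estimated at 1400 nM, with an expected range from 500 nM to 4500 nM.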

Compound 3, half-maximal inhibitory concentration: 510 nM
For compound 3 the middle estimate is 2.7-fold (0.44 log units) above the measured one; measured number inside the range.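

In this assay, methyl in place of hydrogen on a saturated chain carbon bound to an amine nitrogen in a ring gives a 2.9-fold lower number from compound 1 to compound 3 (0.47 log units; beyond the scatter). This is the only measured step shown, and it establishes that this place in the molecule is not silent: the small change from methyl to ethyl moves the read-out beyond the usual scatter, towards stronger inhibition, though only modestly. Compound 2 remains a limit of the assay and yields no step, so this single pair carries the whole reading of the change: the limit of > 10000 nM in this assay, at which 1 of the 3 values shown sits.

Going by these compounds, whether the gain continues with a longer chain such as propyl, or with a branched isopropyl or a benzyl group in this place, stays open. One step also cannot say how a hydroxyethyl chain or a carboxylic acid there would behave, or whether methyl to ethyl would do the same on the core of compound 2.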